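The source may hold more compounds than are shown below. What is called first, only, known or untested is meant among the compounds shown, and "the series" means these compounds.

Measured compounds:
compound 1 `C=C(Br)C(=O)Nc1cccc(-c2cn3nc(Cc4cccc(OC)c4)sc3n2)c1`, 2000 nM
compound 2 `C=C(Br)C(=O)Nc1cccc(-c2cn3nc(-c4ccc(C)cc4)sc3n2)c1`, 920 nM

Going by the values given here, in a functional assay on L1210 cells (Mus musculus) for inhibition, read by cell counting, with a stated time of 2 days (a lower number here means a stronger inhibitor, a higher number a weaker inhibitor), compound 2 holds the lower of the two numbers; the one measured step is a 2.2-fold lower number from compound 1 to compound 2 (0.34 log units; beyond the scatter). Compound 3 `C=C(Br)C(=O)Nc1cccc(-c2cn3nc(-c4cccc(OC)c4)sc3n2)c1` differs from compound 2 by 3-methoxyphenyl in place of 4-methylphenyl on an aromatic carbon. That measured step bears on the change only in part: compound 3 keeps the 3-methoxy substitution seen in compound 1 while retaining the phenyl attachment of compound 2. A modest rise in this assay is therefore expected for compound 3, estimated as a 1.5-fold higher number from compound 2 to compound 3 (0.18 log units; within the scatter), near the edge of the scatter. The expected value for compound 3 is 1400 nM, with a range of 700 nM to 3000 nM.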

Compound 3, half-maximal inhibitory concentration: 580 nM
Compound 3: the middle estimate sits 2.4-fold (0.38 log units) above what was measured, and the stated range ends above it.
By their numbers in this assay, from the lowest: compounds 3 and 2 (each within the scatter of the next); then compound 1.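

Replacing 4-methylphenyl with 3-methoxyphenyl on this aromatic carbon gives a 1.6-fold lower number from compound 2 to compound 3 (0.20 log units; within the scatter) in this assay and so does not separate these two phenyl groups. With the 3-methoxy substitution held constant, 3-methoxyphenyl in place of 3-methoxybenzyl gives a 3.4-fold lower number from compound 1 to compound 3 (0.54 log units; beyond the scatter) and isolates the change from benzyl to directly attached phenyl, which the earlier step mixed with a change of ring substituent. No measurement here accounts for either step. Still open, on these data alone, is whether an amine or a carboxylic acid on this phenyl ring, or a longer chain in place of the benzyl link, would shift the number beyond the scatter.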